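This account rests on a few compounds, and the source may have more. Where it says the series, first, only, none or still open, it means among the compounds named here.

Three hydrazide compounds sharing one core have been measured in a physicochemical assay for lipophilicity, measured as octanol-water partition; on this read-out lower numbers stand for lower lipophilicity and higher numbers for higher lipophilicity. Compound 1, `C/C(=N\NC(=O)COc1cccc2ccccc12)c1ccc(C#N)cc1Br`, gives 3.61. Compound 2, `O=C(COc1cccc2ccccc12)N/N=C/c1ccccc1`, gives 4.02, and compound 3, `COc1cc(/C=N/NC(=O)COc2cccc3ccccc23)cc(OC)c1O`, gives 3.23. Compound 1 thus stands second highest of the three: its nearest neighbour is compound 3, which lies lower by more than the scatter, and compound 2 lies higher by more than the scatter.

Compound 4, `C/C(=N\NC(=O)COc1cccc2ccccc12)c1ccc(Br)cc1`, has not yet been measured in this assay. It differs from compound 1 in one place, where (4-bromophenyl in place of 2-bromo-4-cyanophenyl on a carbon with a double bond to nitrogen). The group that leaves carries one hydrogen-bond acceptor and one triple bond outside aromatic rings; the group that enters carries none. Compound 2, whose aryl group also carries no such acceptor, gives 4.02, the highest of the three.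

On that basis compound 4 is expected to come out above compound 1, with an estimated step of a number 0.59 log units higher from compound 1 to compound 4 (beyond the scatter), beyond the usual scatter. The estimate for compound 4 is 4.2, within a range from 3.7 to 4.7.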

Compound 4, partition coefficient: 3.61
Compound 4: the middle estimate sits 0.59 log units above what was measured, outside the stated range (below it).
By their numbers in this assay, from the lowest: compound 3; then compounds 1 and 4 (each within the scatter of the next); then compound 2.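

Among these compounds, the first step that can be read lies at the carbon with a double bond to nitrogen: in this assay, 4-bromophenyl in place of 2-bromo-4-cyanophenyl gives no change at the digits printed from compound 1 to compound 4 (within the scatter). For this pair, then, the loss of the nitrile, with its triple bond and hydrogen-bond acceptor, comes with no reading that stands outside the scatter, although the change also alters the bromine substitution of the ring. Nothing available here explains why this step is so small.

Because the nitrile and the bromine substitution change together, the compounds shown cannot assign any part of this step to either one. They also leave open what a 4-cyanophenyl group, or a phenyl ring bearing an amine or a carboxylic acid, would give at this place on the shared core.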